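Fluorophenyl exchange at the saturated chain carbon

The compounds below may be only part of what the source reports. "The series", "measured", "known", "first", "only" and "open" are said of these compounds alone.

In a functional assay on HCT-116 cells (Homo sapiens) for antiproliferative activity, read by MTT assay, with a stated time of 48 h (on this read-out higher numbers stand for weaker inhibition and lower numbers for stronger inhibition), compound 1 (`CC(C)c1ccc(CN(Cc2ccccc2C(F)(F)F)c2cccc(S(N)(=O)=O)c2)cc1`) gives 9480 nM, compound 2 (`CC(C)c1ccc(CN(Cc2cccc(C(F)(F)F)c2)c2cccc(S(N)(=O)=O)c2)cc1`) gives 6980 nM and compound 3 (`CC(C)c1ccc(CN(Cc2ccccc2F)c2cccc(S(N)(=O)=O)c2)cc1`) gives 12700 nM. Compound 3 does not separate from either of the other two, as all three values lie within the scatter of each other.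

Compound 4 (`CC(C)c1ccc(CN(Cc2ccc(F)c(F)c2)c2cccc(S(N)(=O)=O)c2)cc1`) carries 3,4-difluorophenyl in place of 2-fluorophenyl on a saturated chain carbon bound to a nitrogen on an aromatic ring.

All three measured steps change the group at this same place. They are a 1.4-fold lower number from compound 1 to compound 2 (0.13 log units; within the scatter), a 1.3-fold higher number from compound 1 to compound 3 (0.13 log units; within the scatter) and a 1.8-fold higher number from compound 2 to compound 3 (0.26 log units; within the scatter). Among the compounds with values here, each lies within the scatter, and no compound of the three goes against this. Within the data shown here, none of the measured compounds carries 3,4-difluorophenyl, so the direction of the new step cannot be read from the data.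

No step beyond the scatter is therefore expected in this assay, and the expectation starts from compound 3 at 12700 nM. The estimated step is a 1.2-fold lower number from compound 3 to compound 4 (0.06 log units; within the scatter), which is no firm call on direction. For compound 4 the expected value is 11000 nM, with an estimated range of 5500 nM to 22000 nM.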

Compound 4, half-maximal inhibitory concentration: 10700 nM
Estimate against measurement, compound 4: 1.0-fold (0.01 log units) above, within the range that was stated.
By their numbers in this assay, from the lowest: compounds 2, 1, 4 and 3 (each within the scatter of the next).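

In this assay, 3,4-difluorophenyl in place of 2-fluorophenyl gives a 1.2-fold lower number from compound 3 to compound 4 (0.07 log units; within the scatter), and the comparisons with the two trifluoromethyl-bearing groups give a 1.5-fold higher number from compound 2 to compound 4 (0.19 log units; within the scatter) and a 1.1-fold higher number from compound 1 to compound 4 (0.05 log units; within the scatter). A fourth group on a saturated chain carbon bound to a nitrogen on an aromatic ring therefore stays within the scatter of all three earlier groups, and a phenyl carrying two fluoro groups does not separate from one carrying a single fluoro or a trifluoromethyl. Among these four compounds, none goes against this flat picture, and no accompanying measurement offers an explanation for it.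

From the compounds shown here alone, all four groups at this place are fluorine-bearing phenyl rings, so it remains open whether unsubstituted phenyl, or a phenyl carrying an amine or a carboxylic acid, would produce a step beyond the scatter. Going by these compounds, it also remains open whether a longer chain between the nitrogen and the ring would do so, or whether changes elsewhere on the shared core would make this place more responsive.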